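The compounds below may be only part of what the source reports. "The series", "measured", "known", "first", "only" and "open" are said of these compounds alone.

Measured compounds:
- compound 1, `CCC(CC)(c1ccc(OCC(O)C(C)(C)C)c(C)c1)c1ccc(C(=O)N[C@@H](C)CO)n1C`: 570 nM
- compound 2, `CCn1c(C(=O)NCCO)ccc1C(CC)(CC)c1ccc(OCC(O)C(C)(C)C)c(C)c1`: 5640 nM

In an assay on HL-60 cells for agonist activity at vitamin D3 receptor (Homo sapiens), with a stated time of 96 h (a higher number here means that more compound is needed for the effect, a lower number that less compound is needed), compound 1 gives 570 nM. Within the data shown here, compound 2 gives 5640 nM in this assay, the highest of the two numbers, with compound 1 as its only neighbour at a gap that lies beyond the scatter. Compound 1 and compound 2 differ in more than one place, so their two values show only the combined outcome, not the weight of any single change.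

Compound 3, `CCn1c(C(=O)N[C@@H](C)CO)ccc1C(CC)(CC)c1ccc(OCC(O)C(C)(C)C)c(C)c1`, is the untested member. It is built from compound 2 by one change: methyl in place of hydrogen on a saturated chain carbon bound to an amide-type nitrogen and a saturated chain carbon. Among the measured compounds shown here, compound 1 carries the same amide side chain as compound 3 and gave the lower number, but no single step isolates this change, so the expectation rests on that loose comparison alone. The step from compound 2 to compound 3 is expected to be a moderate drop, a 2.8-fold lower number from compound 2 to compound 3 (0.45 log units; beyond the scatter). Compound 3 is accordingly estimated at 2000 nM, within 600 nM to 6000 nM.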

Compound 3, half-maximal effective concentration: 1.06 nM
Estimate against measurement, compound 3: 1900-fold (3.28 log units) above; measured number outside the range, below it.
By their numbers in this assay, from the lowest: compound 3; then compound 1; then compound 2.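

In this assay, one added methyl on the saturated chain carbon bound to an amide-type nitrogen, which turns 2-hydroxyethyl into 1-(hydroxymethyl)ethyl, gives a 5300-fold lower number from compound 2 to compound 3 (3.73 log units; beyond the scatter), so this small change in the amide side chain carries great weight. One added methyl on the saturated chain carbon bound to an aromatic nitrogen gives a 540-fold lower number from compound 1 to compound 3 (2.73 log units; beyond the scatter), showing that this second place is just as decisive and that neither effect could be read from compound 1 and compound 2 alone. No other measurement here bears on why either step is so large.

The compounds shown leave open whether a longer chain, such as ethyl in place of the added methyl on the amide side chain or propyl on the aromatic nitrogen, would keep so low a number. They also leave open how the mirror-image form of the 1-(hydroxymethyl)ethyl group would behave.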